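Replacing Anilino with Phenylsulfanyl on the Propynyl Chain

This account rests on a few compounds, and the source may have more. Where it says the series, first, only, none or still open, it means among the compounds named here.

Measured in a functional assay on Ramos cells (Homo sapiens) for antiproliferative activity, read by CCK-8 assay, with a stated time of 48 h; on this read-out higher numbers stand for weaker inhibition and lower numbers for stronger inhibition:
Compound 1 `C=CC(=O)N1CCC[C@@H](n2nc(C#CCOc3ccccc3)c3c(N)ncnc32)C1` gives 8910 nM
Compound 2 `C=CC(=O)N1CCC[C@@H](n2nc(C#CCNc3ccccc3)c3c(N)ncnc32)C1` gives 18200 nM

Of these two compounds, compound 2 holds the higher number at 18200 nM, so it is the weaker inhibitor of the pair in this assay. Its nearest neighbour is compound 1, and the gap is beyond the usual scatter. The next compound, compound 3 `C=CC(=O)N1CCC[C@@H](n2nc(C#CCSc3ccccc3)c3c(N)ncnc32)C1`, has not yet been measured. It differs from compound 2 as follows: phenylsulfanyl in place of anilino on a saturated chain carbon bound to a triple-bonded carbon.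

Among the compounds with values here, only one measured step bears on this change. It exchanges a phenoxy group and the anilino group at the same place on the chain, and it reads a 2.0-fold higher number from compound 1 to compound 2 (0.31 log units; beyond the scatter). That step is modest. Within the data shown here, no measured compound yet carries the phenylsulfanyl group, so any expectation rests on this single comparison, which treats compound 3 as resembling compound 1 at 8910 nM. A modest move toward a lower number is therefore expected, about as large as the measured step. The expected step is a 2.0-fold lower number from compound 2 to compound 3 (0.31 log units; beyond the scatter). For compound 3 the estimated value is 9000 nM, with an expected range of 4000 nM to 19000 nM.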

Compound 3, half-maximal inhibitory concentration: 37200 nM
Compound 3: the middle estimate sits 4.1-fold (0.62 log units) below what was measured; the measured number lies above the stated range.
By their numbers in this assay, from the lowest: compound 1; then compound 2; then compound 3.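

Phenoxy and phenylsulfanyl do not behave alike on this saturated chain carbon, so the earlier comparison of phenoxy with anilino does not carry over to the sulfur-linked group. In this assay, exchanging anilino for phenylsulfanyl gives a 2.0-fold higher number from compound 2 to compound 3 (0.31 log units; beyond the scatter), and exchanging phenoxy for phenylsulfanyl gives a 4.2-fold higher number from compound 1 to compound 3 (0.62 log units; beyond the scatter); across these three compounds the atom that joins the phenyl ring to the chain therefore changes the read-out, and anilino sits in the middle rather than at the weak end, while removing its hydrogen-bond donor does not bring the number down. Nothing shown here explains why the three groups fall in this order.

The compounds shown leave open whether a plain carbon link, as in a 4-phenylbut-1-yn-1-yl chain, would fall within this order or outside it. They also leave open how a longer chain before the phenoxy group, or a saturated amine such as morpholine in place of the anilino group, would read at this position.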